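This account rests on a few compounds, and the source may have more. Where it says the series, first, only, none or still open, it means among the compounds named here.

In a functional assay on HL-60 cells (Homo sapiens) for inhibition, read by MTT assay, with a stated time of 72 h (a lower number here means a stronger inhibitor, a higher number a weaker inhibitor), compound 1 `C=C(C)c1ccc(N2CCN(C(=O)c3oc(C)nc3-c3ccccc3)CC2)cc1` gives "not active" (no number reported), so no number stands against it and it cannot be placed on the scale with the others. Two compounds are measured with numbers. Compound 2 `COc1cc(OC)cc(N2CCN(C(=O)c3onc(C)c3-c3ccccc3)CC2)c1` gives 152 nM in this assay, and compound 3 `CCc1nc(-c2cccc(F)c2)c(C(=O)N2CCN(c3cccc(OC)c3)CC2)o1` gives 201 nM; these two values lie within the usual scatter of each other. Compound 4 `COc1cc(OC)cc(N2CCN(C(=O)c3oc(C)nc3-c3ccccc3)CC2)c1` is still to be measured in this assay. It differs from compound 1 in one place: 3,5-dimethoxyphenyl in place of 4-(1-methylethenyl)phenyl on an amine nitrogen in a ring. Within the data shown here, no step between measured compounds is known for this change, so its size cannot be read from the data. Compound 4 carries the same 3,5-dimethoxyphenyl as compound 2 and the same core as compound 1, one of which has a number and one of which has none. A change toward a measurable value is expected, though with wide uncertainty. Compound 4 is estimated to give 400 nM in this assay, within a range from 100 nM to 3000 nM.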

Compound 4, half-maximal inhibitory concentration: 19.2 nM
Estimate against measurement, compound 4: 21-fold (1.32 log units) above; measured number outside the range, below it.
By their numbers in this assay, from the lowest: compound 4; then compounds 2 and 3 (each within the scatter of the next).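

Among these compounds, compound 1 carries no number, so no step from it to compound 4 can be read. The compounds shown leave open how large a change 3,5-dimethoxyphenyl brings in place of 4-(1-methylethenyl)phenyl on the shared core. Nothing measured here bears on a cause for this result.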